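Trifluoromethyl in place of methyl on the phenyl ring

This account rests on a few compounds, and the source may have more. Where it says the series, first, only, none or still open, it means among the compounds named here.

Compound 3 `COC(=O)C1=C(C)N=C(C)/C(=C(/O)OC)C1c1cccc(N/C(=N/CCNC2CCN(c3ccccc3C)CC2)NC#N)c1` gives 4 nM in an assay on SK-N-MC cells for inhibition of Neuropeptide Y receptor type 1 (Homo sapiens); a lower number here means a stronger inhibitor, a higher number a weaker inhibitor. That number sits level with compound 2 `COC(=O)C1=C(C)N=C(C)/C(=C(/O)OC)C1c1cccc(N/C(=N/CCNC2CCN(c3ccccc3[N+](=O)[O-])CC2)NC#N)c1`, which gives 4 nM, and the two share the lowest value among the three measured compounds; the parent compound 1 `COC(=O)C1=C(C)N=C(C)/C(=C(/O)OC)C1c1cccc(N/C(=N/CCNC2CCN(c3ccccc3)CC2)NC#N)c1` gives 10 nM. Compound 4 `COC(=O)C1=C(C)N=C(C)/C(=C(/O)OC)C1c1cccc(N/C(=N/CCNC2CCN(c3ccccc3C(F)(F)F)CC2)NC#N)c1` differs from compound 3 by trifluoromethyl in place of methyl on an aromatic carbon. Two earlier steps bear on this position: a 2.5-fold lower number from compound 1 to compound 3 (0.40 log units; beyond the scatter) and a 2.5-fold lower number from compound 1 to compound 2 (0.40 log units; beyond the scatter), while no change at the digits printed from compound 2 to compound 3 (within the scatter). Two different groups at this place thus gave the same modest gain, so for compound 4 a step of about no change at the digits printed from compound 3 to compound 4 (within the scatter) is expected, meaning no change beyond the scatter. Compound 4 is therefore estimated at 4 nM, within a range from 1.5 nM to 12 nM.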

Compound 4, half-maximal inhibitory concentration: 14 nM
Compound 4: middle estimate off by 3.5-fold (0.54 log units), on the low side; measured number above the stated range.
By their numbers in this assay, from the lowest: compounds 2 and 3 (each within the scatter of the next); then compounds 1 and 4 (each within the scatter of the next).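

Trifluoromethyl at this place brings a 3.5-fold higher number from compound 3 to compound 4 (0.54 log units; beyond the scatter) and also a 3.5-fold higher number from compound 2 to compound 4 (0.54 log units; beyond the scatter) so the matching results for methyl and nitro do not extend to every group. Against hydrogen it brings a 1.4-fold higher number from compound 1 to compound 4 (0.15 log units; within the scatter) so the modest gain seen with methyl and nitro does not appear with this group. Nothing available here says why the groups differ.

As far as these compounds go, whether chlorine, fluorine or a methoxy group at this place would behave like methyl or like trifluoromethyl remains open. So does how any of these groups would behave on another carbon of the phenyl ring.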